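A Chloro Group Added to the Core of Compound 1

This account rests on a few compounds, and the source may have more. Where it says the series, first, only, none or still open, it means among the compounds named here.

Compound 1 `COc1ccc(NC(=O)C(=O)c2cn(C(C)C)c3ccccc23)cn1`: 85 nM
Compound 2 `CCCCn1cc(C(=O)C(=O)Nc2ccc(OC)nc2)c2ccccc21`: 18 nM

In a functional assay on FaDu cells (Homo sapiens) for cytotoxicity, read by MTT assay, with a stated time of 72 h (on this read-out lower numbers stand for higher toxicity in this test and higher numbers for lower toxicity in this test), compound 1 gives 85 nM, the highest of the two numbers shown, and the nearest number belongs to compound 2 with 18 nM. For the measured compounds named here, the one measured step, a 4.7-fold lower number from compound 1 to compound 2 (0.67 log units; beyond the scatter), comes from a change on the aromatic nitrogen, not on the ring carbons.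

Compound 3 `COc1ccc(NC(=O)C(=O)c2cn(C(C)C)c3cccc(Cl)c23)cn1` differs from compound 1 by chloro in place of hydrogen on an aromatic carbon. Going by the values given here, no measured step touches that position, so nothing among the numbers bears directly on this change, and no direction can be read from them. The expectation for compound 3 is therefore a step of no change at the digits printed from compound 1 to compound 3 (within the scatter), staying within the usual scatter. The estimate for compound 3 in this assay is 85 nM, with a range from 25 nM to 300 nM.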

Compound 3, concentration lethal to 50% of the cells: 2130 nM
Beside the measured number, compound 3's estimate is 25-fold (1.40 log units) below it, and the stated range ends below it.
By their numbers in this assay, from the lowest: compound 2; then compound 1; then compound 3.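

In this assay a single chloro in place of hydrogen, on an aromatic carbon of the core of compound 1, gives a 25-fold higher number from compound 1 to compound 3 (1.40 log units; beyond the scatter) on its own. So this ring position is far from indifferent: one added atom here moves the number strongly toward lower toxicity in this test, which the earlier step, made on the aromatic nitrogen, could not reveal. Nothing available here explains why this one atom changes the result so much.

Still open, from the compounds shown here alone, is whether this rise belongs to chloro itself or would also appear with fluoro, a methyl group or an amine on the same carbon. Going by these compounds, it is also open whether chloro at this position would have the same effect with the butyl group of compound 2 on the aromatic nitrogen.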